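Exchanging the Sulfonyl Aryl Group of Compound 1

The source may hold more compounds than are shown below. What is called first, only, known or untested is meant among the compounds shown, and "the series" means these compounds.

Compound 1 `O=S(=O)(Nc1ccc(-c2nc3ccccc3o2)cc1)c1ccc(Cl)s1` gives 31000 nM in an assay on cells for inhibition of HSP60/HSP10 (Homo sapiens), with a stated time of 60 min; on this read-out lower numbers stand for stronger inhibition and higher numbers for weaker inhibition. Of the two values in this assay that are numbers, it stands at the top, yet compound 3 `O=[N+]([O-])c1cc(S(=O)(=O)Nc2ccc3oc(-c4ccccc4)nc3c2)ccc1Cl` at 17000 nM lies within the scatter of it. Compound 2 `O=S(=O)(Nc1ccc2oc(-c3ccccc3)nc2c1)c1ccc(Cl)c(C(F)(F)F)c1` yields only a limit, > 100000 nM, and not a number. Among the compounds with values here, the single step among measured compounds, an at least 5.8-fold lower number from compound 2 to compound 3 (0.76 log units; beyond the scatter), with nitro in place of trifluoromethyl on an aromatic carbon, touches the aryl group on the sulfonyl sulfur but on a core other than that of compound 1, and neither compound carries the thiophene.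

Compound 4 `O=S(=O)(Nc1ccc(-c2nc3ccccc3o2)cc1)c1ccc(Cl)c(Cl)c1` differs from compound 1 by 3,4-dichlorophenyl in place of 5-chlorothiophen-2-yl on a sulfonyl sulfur. Within the data shown here, no measured step covers this exchange, so only the general weight of the sulfonyl aryl group seen in compound 2 and compound 3 can guide the view. On that basis the step is expected to fall within the scatter: a 1.2-fold lower number from compound 1 to compound 4 (0.09 log units; within the scatter). Compound 4 is therefore estimated at 25000 nM in this assay, between 8000 nM and 80000 nM.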

Compound 4, half-maximal inhibitory concentration: 25000 nM
Beside the measured number, compound 4's estimate shows no gap at the digits printed, and the stated range covers the measured number.
By their numbers in this assay, from the lowest: compounds 3, 4 and 1 (each within the scatter of the next). At a limit, above all of these: compound 2.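

In this assay, the exchange on the sulfonyl sulfur of the core of compound 1 gives a 1.2-fold lower number from compound 1 to compound 4 (0.09 log units; within the scatter) with 3,4-dichlorophenyl in place of 5-chlorothiophen-2-yl. Within the data shown here, this is the first measured step at this position on that core, and it shows that the five-membered aromatic ring with its sulfur atom is not required to hold the read-out at this level, as a six-membered aromatic ring of carbon only serves equally well here. Nothing given here accounts for this step through a measured property of either group.

On these data alone, it stays open how an amine or a carboxylic acid in place of chlorine on the sulfonyl aryl group would read on this core. Among these compounds, whether nitro in place of trifluoromethyl, seen only on the core shared by compound 2 and compound 3, would have a similar effect on the core of compound 1 also remains open.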